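A few compounds are considered here, and "the series" means these few. Any claim that something is new, unique, unknown or untested is made for them only; others in the source may bear on it.

Compound 1 `Cc1cc(O)c(C(=O)/C=C/c2ccccc2[N+](=O)[O-])c(=O)o1`: > 100000 nM
Compound 2 `Cc1cc(O)c(C(=O)/C=C/c2ccccc2Cl)c(=O)o1`: > 100000 nM

In a functional assay on HCT-116 cells (Homo sapiens) for cytotoxicity, read by MTT assay (a lower number here means a stronger inhibitor, a higher number a weaker inhibitor), compound 2 gives > 100000 nM, which is a limit of the assay. Compound 1 gives > 100000 nM, which is also a limit. The data so far therefore come down to one entry: the limit of > 100000 nM in this assay, at which 2 of the 2 values shown sit.

Compound 3 `COc1ccccc1/C=C/C(=O)c1c(O)cc(C)oc1=O` keeps the shared core of compound 2 and carries methoxy in place of chloro on an aromatic carbon, ortho to a large group: methoxy in place of chloro on an aromatic carbon. Among the compounds with values here, the one measured step that bears on this change is a step that the two limits leave unreadable from compound 1 to compound 2, also a swap of one group for another on an aromatic carbon. Its size cannot be read, so it offers no measure of how far such a swap moves the result. With no readable step to go on, no step beyond the scatter is expected in this assay, and no direction can be given. Compound 3 will most likely also be reported only as a limit. Compound 3 is estimated at 100000 nM, with an expected range from 40000 nM to 200000 nM. The estimated step is a number no higher from compound 2 to compound 3 (the limit leaves the size open).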

Compound 3, half-maximal inhibitory concentration: > 100000 nM
Compound 3: a limit, no number; the forecaster's own chance of this, stated with the estimate: 65%; the middle value lies on the limit itself.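

Compound 3, like compound 1 and compound 2, is reported only as a limit in this assay, so neither of its steps from those two compounds can be read: the limit of > 100000 nM in this assay, at which 3 of the 3 values shown sit.

The compounds shown leave open how chloro, nitro and methoxy compare in this assay, and whether any swap on this aromatic carbon would give a readable number.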